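This account rests on a few compounds, and the source may have more. Where it says the series, first, only, none or still open, it means among the compounds named here.

Going by the values given here, compound 3 `CC(=O)N1CCN(Cc2nc3ccccc3n2Cc2cccc(C)c2)CC1` stands at the top of the three numbers so far: in an assay on isolated protein for inhibition of aldehyde dehydrogenase 1A1 (Homo sapiens), read by spectrophotometry, tested at 10 uM (on this read-out higher numbers stand for more inhibition at the one concentration tested (going by the name of the read-out) and lower numbers for less inhibition), compound 3 gives 70.3%. Its nearest neighbour, compound 2 `CCc1ccc(C(=O)N2CCN(Cc3nc4ccccc4n3Cc3cccc(C)c3)CC2)cc1`, gives 67%, and a number 3.3 percentage points higher from compound 2 to compound 3 (within the scatter) lies within the scatter, so compounds 2 and 3 cannot be told apart on this evidence. Compound 1 `Cc1cccc(Cn2c(CN3CCN(C(=O)c4cccnc4)CC3)nc3ccccc32)c1` gives 24.5%; here a number 45.8 percentage points higher from compound 1 to compound 3 (beyond the scatter) and a number 42.5 percentage points higher from compound 1 to compound 2 (beyond the scatter) are both well beyond the scatter.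

The next compound, compound 4 `CCC(=O)N1CCN(Cc2nc3ccccc3n2Cc2cccc(C)c2)CC1`, differs from compound 3 in one place: methyl in place of hydrogen on a saturated chain carbon bound to a carbonyl carbon. Among the compounds with values here, no measured pair covers exactly this small change. What bears on it is the swap on the carbonyl carbon between compounds 2 and 3, where a far larger exchange of groups, 4-ethylphenyl for methyl, gave only a number 3.3 percentage points higher from compound 2 to compound 3 (within the scatter); the large steps from compound 1 involve pyridin-3-yl, which compound 4 does not carry. A single extra carbon on the chain is therefore expected to leave the read-out about where compound 3 sits.

For compound 4 the expected step is a number 2.3 percentage points lower from compound 3 to compound 4 (within the scatter), within the scatter. Compound 4 is estimated at 68%, in a range from 50% to 82%.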

Compound 4, a percentage reported as inhibition, at one concentration (the size of the read-out at that concentration, not a potency): 85.1%
Compound 4: the middle estimate sits 17.1 percentage points below what was measured, and the stated range ends below it.
By their numbers in this assay, from the lowest: compound 1; then compounds 2 and 3 (each within the scatter of the next); then compound 4.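

Going from acetyl to propanoyl, a single methyl on a saturated chain carbon bound to a carbonyl carbon, gives in this assay a number 14.8 percentage points higher from compound 3 to compound 4 (beyond the scatter) and so shows that this position can respond to one added carbon, which the exchange of 4-ethylphenyl for methyl on the same carbonyl carbon had not suggested. Ethyl on the carbonyl carbon also stands clear of both ring-bearing groups, with a number 18.1 percentage points higher from compound 2 to compound 4 (beyond the scatter) and with a number 60.6 percentage points higher from compound 1 to compound 4 (beyond the scatter) in the same comparison, which puts compound 4 at the top of this set. Nothing available here explains why the extra methyl has this effect.

From the compounds shown here alone, whether the number keeps rising with a longer chain such as butanoyl, or with a branched chain such as isobutyryl, remains open. So does how an amine or a carboxylic acid at the end of that chain would read.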